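Fluoro for Methoxy on a Weakly Inhibiting Aminophenyl Series

The source may report more compounds than this note shows. Statements on the series, on what has been measured and on what is new or still open speak of the compounds shown alone.

Measured so far:
compound 1, `Nc1cccc(-c2cn3nc(Cc4ccccc4)sc3n2)c1`, 37000 nM
compound 2, `COc1ccc(-c2nn3cc(-c4cccc(N)c4)nc3s2)cc1`, >= 250000 nM

Compound 1 (`Nc1cccc(-c2cn3nc(Cc4ccccc4)sc3n2)c1`) was tested in a functional assay on CCRF-CEM cells (Homo sapiens) for inhibition, read by cell counting, with a stated time of 3 days (on this read-out higher numbers stand for weaker inhibition and lower numbers for stronger inhibition), where compound 1 gives 37000 nM. Compound 2 (`COc1ccc(-c2nn3cc(-c4cccc(N)c4)nc3s2)cc1`) has no number in this assay, only a limit: compound 2 gives >= 250000 nM. Where compound 2 stands is therefore known only as the limit of >= 250000 nM in this assay, at which 1 of the 2 values shown sits, and nothing finer can be said about it.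

Compound 3 (`Nc1cccc(-c2cn3nc(-c4ccc(F)cc4)sc3n2)c1`) has not yet been measured. It differs from compound 2 by fluoro in place of methoxy on an aromatic carbon. Among the compounds with values here, no step between two measured compounds is available here, so no measured change in this assay can be pointed to for guidance, and the two values shown only say that compound 1 gives a number while compound 2 does not.

The estimate for compound 3 in this assay is 150000 nM, expected to lie between 40000 nM and 300000 nM. This estimate means a step of an at least 1.6-fold lower number from compound 2 to compound 3 (0.22 log units; that floor lies within the scatter), expected at best as a modest gain, with a real chance that the assay again returns only a limit.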

Compound 3, half-maximal inhibitory concentration: >= 250000 nM
Compound 3: a limit, no number; the forecaster's own chance of this, stated with the estimate: 45%; at least 1.6-fold (0.22 log units) between middle value and limit.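

In this assay, within the data shown here, the one step that can be read is an at least 6.7-fold higher number from compound 1 to compound 3 (0.82 log units; beyond the scatter), so 4-fluorophenyl in place of benzyl on an aromatic carbon weakens inhibition by more than the scatter. Fluoro in place of methoxy, on an aromatic carbon para to a large group, does not bring back a number, and the step between compound 2 and compound 3 cannot be read. Compound 3 therefore stands with compound 2 at the limit, which leaves compound 1, with its benzyl, as the only compound shown that gives a number in this assay: the limit of >= 250000 nM in this assay, at which 2 of the 3 values shown sit.

On these data alone, how fluoro and methoxy compare at this position stays open; neither compound 2 nor compound 3 gives a number to set against the other. As far as these compounds go, it also remains open whether an amine or a carboxylic acid in place of fluoro, or a longer chain in place of benzyl, would give a number in this assay.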